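Ring contraction on the thiocarbonyl of a long-chain phosphate

This account rests on a few compounds, and the source may have more. Where it says the series, first, only, none or still open, it means among the compounds named here.

Measured compounds:
compound 1 `CCCCCCCCCCCCCCCCOP(=O)(O)OCCSC(=S)N1CCCCC1`, 14700 nM
compound 2 `CCCOP(=O)(O)OCCSC(=S)N1CCCCCC1`, 86100 nM
compound 3 `CCCCCCCCOP(=O)(O)OCCSC(=S)N1CCCCC1`, limit only

In a functional assay on DU-145 cells (Homo sapiens) for inhibition, read by MTT assay, with stated times of 18 h and 4 h (on this read-out higher numbers stand for weaker inhibition and lower numbers for stronger inhibition), compound 1 gives 14700 nM, the lowest of the two numbers given, with compound 2 at 86100 nM beyond the scatter from it. Compound 3 is reported only as a limit, > 100000 nM, and no number is given for it (the limit of > 100000 nM in this assay, at which 1 of the 3 values shown sits). Among the measured compounds shown here, the one single-place step, an at least 6.8-fold higher number from compound 1 to compound 3 (0.83 log units; beyond the scatter), concerns hydrogen in place of octyl on the chain and says nothing about the ring on the thiocarbonyl carbon. Compound 2 differs from compound 1 in both chain and ring, so its value cannot be split between the two changes.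

Compound 4 `CCCCCCCCCCCCCCCCOP(=O)(O)OCCSC(=S)N1CCCC1` keeps the chain of compound 1 and carries pyrrolidin-1-yl in place of piperidin-1-yl on a thiocarbonyl carbon. For the measured compounds named here, no measured step bears on this change, so no step beyond the scatter is expected in this assay, and a 1.4-fold higher number from compound 1 to compound 4 (0.13 log units; within the scatter) is the estimate for that step. Compound 4 is therefore expected to give about 20000 nM, between 7000 nM and 60000 nM.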

Compound 4, half-maximal inhibitory concentration: 28900 nM
Compound 4: middle estimate off by 1.4-fold (0.16 log units), on the low side; the measured number falls inside the stated range.
By their numbers in this assay, from the lowest: compounds 1 and 4 (each within the scatter of the next); then compound 2. At a limit, above all of these: compound 3.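

With the chain of compound 1 held fixed, this is the only step shown that isolates the group on the thiocarbonyl carbon: in this assay, pyrrolidin-1-yl in place of piperidin-1-yl gives a 2.0-fold higher number from compound 1 to compound 4 (0.29 log units; within the scatter) and stays within the scatter. At this position on the long chain, the one six-membered non-aromatic ring can therefore give way to the one five-membered non-aromatic ring without a step beyond the scatter, whereas the earlier single-place step concerned only the chain. Nothing measured here accounts for the size of this step.

On these data alone, whether an open-chain amine such as diethylamino, or a ring with a second hetero atom such as morpholin-4-yl, is tolerated on the thiocarbonyl carbon remains open. As far as these compounds go, whether pyrrolidin-1-yl and piperidin-1-yl also stay within the scatter on a shorter chain is equally open.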